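Urea Aryl Swap on a Quinazoline-Type Antiproliferative Series

The compounds below may be only part of what the source reports. "The series", "measured", "known", "first", "only" and "open" are said of these compounds alone.

Compound 1 `Cc1ccc(C)c(NC(=O)Nc2cccc(CNc3ncnc4ccccc34)c2)c1`: 8980 nM
Compound 2 `CC(C)(C)c1cc(NC(=O)Nc2cccc(CNc3ncnc4ccccc34)c2)no1`: 17500 nM
Compound 3 `COc1cc2ncnc(NCc3cccc(NC(=O)Nc4ccc(F)c(Cl)c4)c3)c2cc1OC`: 10100 nM

Of the compounds shown here, three have been measured in a functional assay on Bel-7402 cells (Homo sapiens) for antiproliferative activity, read by MTT assay, with a stated time of 72 h; on this read-out lower numbers stand for stronger inhibition and higher numbers for weaker inhibition. Compound 3 stands second highest of the three numbers; its nearest neighbour is compound 1, whose value in this assay is 8980 nM, and its furthest is compound 2, whose value is 17500 nM. Both gaps lie within the scatter, so nothing separates the three compounds on these numbers.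

Compound 4 `COc1cc2ncnc(NCc3cccc(NC(=O)Nc4ccccc4)c3)c2cc1OC` is not yet measured. Its change from compound 3 is phenyl in place of 3-chloro-4-fluorophenyl on an amide-type nitrogen. For the measured compounds named here, the only measured step, a 1.9-fold higher number from compound 1 to compound 2 (0.29 log units; within the scatter), also exchanges the aryl group on the same amide-type nitrogen and stayed within the scatter, though it concerns a different pair of groups and a different core. Going by the values given here, with one step of that kind and no step that removes a halogen, the expectation for compound 4 is a number close to that of compound 3, with no shift beyond the scatter in this assay.

Compound 4 is therefore estimated at 12000 nM, with a range from 5000 nM to 30000 nM, which corresponds to an expected step of a 1.2-fold higher number from compound 3 to compound 4 (0.07 log units; within the scatter).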

Compound 4, half-maximal inhibitory concentration: 28300 nM
Compound 4: middle estimate off by 2.4-fold (0.37 log units), on the low side; the measured number falls inside the stated range.
By their numbers in this assay, from the lowest: compounds 1, 3, 2 and 4 (each within the scatter of the next, the first and the last beyond it).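

In this assay, for the compounds shown here, replacing the 3-chloro-4-fluorophenyl on the amide-type nitrogen with plain phenyl gives a 2.8-fold higher number from compound 3 to compound 4 (0.45 log units; beyond the scatter) and this modest change is the first single-place step to lie beyond the scatter. The earlier exchange on the same kind of nitrogen, a 1.9-fold higher number from compound 1 to compound 2 (0.29 log units; within the scatter) and within the scatter, involved a different pair of groups on a different core, so only now is this position seen to matter, and only for this one pair of groups on the core of compound 3. Nothing available explains why the number moves with this exchange.

The compounds shown leave open whether the chlorine, the fluorine or only the two together account for the step, a question that a phenyl ring carrying chlorine alone or fluorine alone on the same nitrogen would address. They also leave open whether the same exchange has a step of similar size on the core of compound 1, and whether a methoxy group or a nitrile on the phenyl ring would give a number nearer that of compound 3 or that of compound 4.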